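Shortening the amide side chain of a spiro-piperidine cholesterol transporter ligand

A few compounds are considered here, and "the series" means these few. Any claim that something is new, unique, unknown or untested is made for them only; others in the source may bear on it.

Compound 1 `CC(C)(C)c1ccc(C(=O)N2CCC3(CC2)C(=O)N(CC(=O)N2CCNCC2)CN3c2ccccc2)cc1` and compound 2 `CC(C)(C)OC(=O)NCCCCCNC(=O)CN1CN(c2ccccc2)C2(CCN(C(=O)c3ccc(C(C)(C)C)cc3)CC2)C1=O` share one core and were both tested in an assay on HEK293 cells for displacement of a labelled ligand from NPC1-like intracellular cholesterol transporter 1 (Homo sapiens); a lower number here means a stronger inhibitor, a higher number a weaker inhibitor. Compound 1 gives 22000 nM in this assay. Compound 2 gives 13700 nM, the lowest of the two numbers, though its gap to compound 1 lies within the usual scatter, so the two cannot be ordered. Compound 3 `CC(C)(C)c1ccc(C(=O)N2CCC3(CC2)C(=O)N(CC(=O)NCCO)CN3c2ccccc2)cc1` has not yet been measured in this assay. It differs from compound 2 in one place: hydroxy in place of 3-((tert-butoxycarbonyl)amino)propyl on a saturated chain carbon, two bonds along the chain from an amide-type nitrogen. Within the data shown here, no pair of measured compounds that differ in a single place is available, so there is no measured step to anchor the change. Both measured compounds sit at weak inhibition, and the expectation for compound 3 is a step of a 1.1-fold higher number from compound 2 to compound 3 (0.04 log units; within the scatter), that is, nothing beyond the scatter in either direction. Compound 3 is therefore estimated at 15000 nM, with a range from 5000 nM to 50000 nM.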

Compound 3, half-maximal inhibitory concentration: 1000 nM
Compound 3: the middle estimate sits 15-fold (1.18 log units) above what was measured; measured number outside the range, below it.
By their numbers in this assay, from the lowest: compound 3; then compounds 2 and 1 (each within the scatter of the next).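

In this assay, this position proves sensitive to the group it carries, which the two earlier compounds, within the scatter of each other, did not reveal. Hydroxy in place of 3-((tert-butoxycarbonyl)amino)propyl gives a 14-fold lower number from compound 2 to compound 3 (1.14 log units; beyond the scatter) on the saturated chain carbon, and (2-hydroxyethyl)amino in place of piperazin-1-yl gives a 22-fold lower number from compound 1 to compound 3 (1.34 log units; beyond the scatter) on the carbonyl carbon, so two quite different side chains both lose out to the same hydroxy-ended chain. Nothing measured here explains this gain.

The compounds shown do not separate the part played by the hydroxy from that of the short chain; a methoxy or a plain ethyl group would bear on that. On these data alone, how an amine, a carboxylic acid or a longer chain ending in hydroxy would read in this assay also remains open.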